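Replacing furan-2-yl with phenyl in a hydroxyphenyl pyridine series

A few compounds are considered here, and "the series" means these few. Any claim that something is new, unique, unknown or untested is made for them only; others in the source may bear on it.

Three compounds share a core carrying a 4-hydroxyphenyl group. Compound 1 `Oc1ccc(-c2cc(-c3ccccc3)nc(-c3ccc(Cl)cc3)c2)cc1` gives 4270 nM in a functional assay on T47D cells (Homo sapiens) for cytotoxicity, read by CCK-8 assay and cell counting, with a stated time of 2 days; on this read-out higher numbers stand for weaker inhibition and lower numbers for stronger inhibition. Compound 2 `Oc1ccc(-c2cc(-c3ccsc3)nc(-c3cccc(Cl)c3)c2)cc1` gives 7390 nM in this assay. Compound 3 `Oc1ccc(-c2cc(-c3cccc(Cl)c3)nc(-c3ccco3)c2)cc1` gives 5220 nM in this assay and stands second highest of the three numbers; its nearest neighbour is compound 1 and its furthest is compound 2, and both gaps are within the scatter. Within the data shown here, the one single-point step among the measured compounds, from compound 2 to compound 3, shows a 1.4-fold lower number from compound 2 to compound 3 (0.15 log units; within the scatter), a change the scatter can account for.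

Compound 4 `Oc1ccc(-c2cc(-c3ccccc3)nc(-c3cccc(Cl)c3)c2)cc1` differs from compound 3 in one place: phenyl in place of furan-2-yl on an aromatic carbon. Among the measured compounds shown here, no measured step swaps a five-membered heteroaryl for phenyl at this position, so the only guide is that the heteroaryl exchange from compound 2 to compound 3 moved little, and that compound 1, which also carries phenyl but with a 4-chlorophenyl rather than a 3-chlorophenyl, sits close to compound 3. Compound 4 is therefore expected to show a step of about a 1.1-fold lower number from compound 3 to compound 4 (0.05 log units; within the scatter), which is no movement beyond the scatter. The estimate for compound 4 in this assay is 4600 nM, with a range from 2000 nM to 10500 nM.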

Compound 4, half-maximal inhibitory concentration: 4790 nM
Compound 4: the middle estimate sits 1.0-fold (0.02 log units) below what was measured; low and high end bracket the measured number.
By their numbers in this assay, from the lowest: compounds 1, 4, 3 and 2 (each within the scatter of the next).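

In this assay, phenyl on the aromatic carbon next to the ring nitrogen gives a 1.1-fold lower number from compound 3 to compound 4 (0.04 log units; within the scatter) when it replaces furan-2-yl, and a 1.5-fold lower number from compound 2 to compound 4 (0.19 log units; within the scatter) when it replaces thiophen-3-yl. Among these compounds, this is the first view of a six-membered aromatic ring of carbon only at this position, and across furan-2-yl, thiophen-3-yl and phenyl no step leaves the scatter, even though furan-2-yl carries 1 hydrogen-bond acceptor and phenyl carries 0. Among the compounds shown here, compound 4 also gives the first matched pair for the chlorophenyl group, with a 1.1-fold higher number from compound 1 to compound 4 (0.05 log units; within the scatter) for 3-chlorophenyl in place of 4-chlorophenyl, so that exchange too stays within the scatter while phenyl is held at the position next to the ring nitrogen.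

Every group shown at this position is an aromatic ring, so how an amine, a carboxylic acid or a longer chain on the same carbon would read in this assay remains open. Nothing at hand offers an explanation for how small these steps are.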